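One Aryl Swap in an Antiproliferative Series

The source may report more compounds than this note shows. Statements on the series, on what has been measured and on what is new or still open speak of the compounds shown alone.

In a functional assay on K562 cells (Homo sapiens) for antiproliferative activity, read by MTT assay, with a stated time of 48 h (on this read-out lower numbers stand for stronger inhibition and higher numbers for weaker inhibition), compound 1 `O=C1Nc2ccc(-c3ccc(C(F)(F)F)cc3)cc2C1=O` gives > 10000 nM, which is a limit of the assay and not a number. Compound 2 `COc1ccc(-c2ccc3c(c2)C(=O)C(=O)N3Cc2cc(C)cc(C)c2)cc1` gives 140 nM. Compound 3 `COc1ccc(CN2C(=O)C(=O)c3cc(-c4cc(OC)cc(OC)c4)ccc32)cc1` gives 510 nM, the higher of the two actual numbers, and its gap to compound 2 lies beyond the scatter, so it is the weaker of this pair. Compound 4 `COc1ccc(CN2C(=O)C(=O)c3cc(-c4ccc(OC(C)C)cc4)ccc32)cc1` has 4-isopropoxyphenyl in place of 3,5-dimethoxyphenyl on an aromatic carbon. Within the data shown here, no measured pair isolates this swap, so the expectation is cautious. The expected step of a 1.3-fold lower number from compound 3 to compound 4 (0.11 log units; within the scatter) is small, within the scatter, with no firm direction in this assay. For compound 4 the estimated value is 400 nM, with an expected range from 120 nM to 1500 nM.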

Compound 4, half-maximal inhibitory concentration: 310 nM
Beside the measured number, compound 4's estimate is 1.3-fold (0.11 log units) above it; measured number inside the range.
By their numbers in this assay, from the lowest: compound 2; then compounds 4 and 3 (each within the scatter of the next). At a limit, above all of these: compound 1.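

At this aromatic carbon, 4-isopropoxyphenyl in place of 3,5-dimethoxyphenyl gives a 1.6-fold lower number from compound 3 to compound 4 (0.22 log units; within the scatter) in this assay. This is the first comparison shown that changes only one place, and it shows that moving from the two methoxy groups to one isopropoxy group, with one oxygen fewer, brings no change that can be read in this assay. Nothing in the data shown bears on why.

Going by these compounds, what remains open is how this position responds when the aryl ring carries something other than an ether, such as an amine or a carboxylic acid. A step large enough to stand beyond the scatter at this position also remains to be seen.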